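Changing the amide group of compound 2

This account rests on a few compounds, and the source may have more. Where it says the series, first, only, none or still open, it means among the compounds named here.

Within the data shown here, in a functional assay on HCT-116 cells (Homo sapiens) for inhibition, read by sulforhodamine B assay, with a stated time of 2 days (on this read-out higher numbers stand for weaker inhibition of growth and lower numbers for stronger inhibition of growth), compound 2 `CC1=C(C(=O)Nc2ccc(C)cc2)C(c2ccc(O)cc2O)NC(NCc2ccccc2)=N1` gives 66700 nM, the highest of the three numbers measured so far. Compound 3 `CC1=C(C(=O)Nc2ccc(C)cc2)C(c2ccc(O)cc2O)NC(Nc2ccc([N+](=O)[O-])cc2Cl)=N1` gives 28200 nM. The compound still to be measured, compound 4 `CC1=C(C(=O)Nc2cccc([N+](=O)[O-])c2)C(c2ccc(O)cc2O)NC(NCc2ccccc2)=N1`, keeps the benzyl group on the amine nitrogen of compound 2 and alters only the amide: 3-nitrophenyl in place of 4-methylphenyl on an amide-type nitrogen. In short, 3-nitrophenyl stands in place of 4-methylphenyl on an amide-type nitrogen.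

Among the measured compounds shown here, the one measured step, a 2.4-fold lower number from compound 2 to compound 3 (0.37 log units; beyond the scatter), is modest but was made on the amine nitrogen, so it bears on the amide change only indirectly. The closest evidence comes from a compound that differs from compound 4 elsewhere but shares its 3-nitrophenyl group: compound 1 `CC1=C(C(=O)Nc2cccc([N+](=O)[O-])c2)C(c2ccc(O)cc2O)NC(SCc2ccccc2)=N1` gives 29000 nM. For the measured compounds named here, that value points towards a lower number, though no measured pair isolates the amide change. A small step is therefore expected, and the estimate is a 1.6-fold lower number from compound 2 to compound 4 (0.20 log units; within the scatter). Compound 4 is estimated at 42000 nM, with an expected range of 20000 nM to 85000 nM.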

Compound 4, concentration for 50% growth inhibition: > 100000 nM
Compound 4: a limit, no number; the forecaster's own chance of this, stated with the estimate: 10%; middle value at least 2.3-fold (0.37 log units) away from the limit.
By their numbers in this assay, from the lowest: compounds 3 and 1 (each within the scatter of the next); then compound 2. At a limit, above all of these: compound 4.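

The reading for compound 4 in this assay is a limit and not a number: the limit of > 100000 nM in this assay, at which 1 of the 4 values shown sits. On the amide-type nitrogen, 3-nitrophenyl in place of 4-methylphenyl gives an at least 1.4-fold higher number from compound 2 to compound 4 (0.17 log units; that floor lies within the scatter), so this change brought no lower number, and the 3-nitrophenyl group alone does not account for the lower reading of compound 1. Among these compounds, with that group kept, benzylamino in place of benzylsulfanyl on a carbon with a double bond to nitrogen gives an at least 3.4-fold higher number from compound 1 to compound 4 (0.53 log units; beyond the scatter), the first measured step at this place and the only new one that clearly exceeds the scatter.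

On these data alone, what remains open is how a 3-aminophenyl group on the amide-type nitrogen would read with the benzylamino group kept. Also open, as far as these compounds go, is whether the amide change would read the same alongside the 2-chloro-4-nitrophenyl group of compound 3.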